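A few compounds are considered here, and "the series" means these few. Any claim that something is new, unique, unknown or untested is made for them only; others in the source may bear on it.

Compound 1 `O=C(CCCCC1CCSS1)Nc1ccccn1` and compound 2 `O=C(CCCCC1CCSS1)Nc1ccc(Cl)cn1` share a core that carries a five-membered disulfide ring, while compound 3 `O=C(CCCCC(CCSC(=O)c1ccccc1)SC(=O)c1ccccc1)Nc1ccccc1` and compound 4 `O=C(CCCCC(CCSC(=O)c1ccccc1)SC(=O)c1ccccc1)Nc1ccccc1Cl` share a core in which that ring is opened and both sulfur atoms carry benzoyl groups; the difference between the two cores is not broken down here. In a functional assay on Bel-7402 cells (Homo sapiens) for inhibition, read by MTT assay, with a stated time of 24 h, tested at 10 ug/mL (on this read-out lower numbers stand for less inhibition of growth and higher numbers for more inhibition of growth at the one concentration tested), compound 1 gives 5.77%, and in this assay compound 2 gives 16.1%. The change from compound 1 to compound 2 is chloro in place of hydrogen on an aromatic carbon and it made a step of a number 10.3 percentage points higher from compound 1 to compound 2 (beyond the scatter). Compound 3 is reported in this assay as "not active" (no number reported), without a number.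

The change from compound 3 to compound 4 is chloro in place of hydrogen on an aromatic carbon. For the measured compounds named here, it is the same kind of change as the one from compound 1 to compound 2, but not the same: in the earlier pair the chloro enters on a six-membered aromatic ring with one nitrogen, two atoms from the ring nitrogen and para to a large group, whereas here it enters on a six-membered aromatic ring of carbon only, ortho to a large group.

Going by the values given here, because compound 3 stands at "not active" (no number reported) and the only measured step of this kind, a number 10.3 percentage points higher from compound 1 to compound 2 (beyond the scatter), is modest, compound 4 is expected to remain weak in this assay. Compound 4 is estimated at 10% in this assay, with a range expected from 0% to 25%.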

Compound 4, percent growth inhibition at one concentration: 6.63%
Beside the measured number, compound 4's estimate is 3.4 percentage points above it; low and high end bracket the measured number.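

In this assay compound 3 is reported as "not active" (no number reported) and compound 4 gives 6.63% so no step can be read between compound 3 and compound 4. Nothing available accounts for this result. The compounds shown leave open whether chloro in place of hydrogen acts alike on the two cores, and how the cores themselves compare.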